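From Hydroxy to Isopropoxy on a Shared Core

The source may report more compounds than this note shows. Statements on the series, on what has been measured and on what is new or still open speak of the compounds shown alone.

Compound 1, `O=C1c2cccc(F)c2C(=O)C1(O)O`: > 100000 nM
Compound 2, `O=C1c2cccc(O)c2C(=O)C1(O)O`: > 100000 nM

In an assay on isolated protein for inhibition of carbonic anhydrase 4 (Homo sapiens), read by stopped-flow, with a stated time of 15 min (on this read-out lower numbers stand for stronger inhibition and higher numbers for weaker inhibition), compound 2 stands at a limit, not a number. The step that the two limits leave unreadable from compound 1 to compound 2 cannot be read because both compounds sit at the limit of > 100000 nM in this assay, at which 2 of the 2 values shown sit. Compound 3, `CC(C)Oc1cccc2c1C(=O)C(O)(O)C2=O`, differs from compound 2 by isopropyl in place of hydrogen on an oxygen on an aromatic ring. No measured step of readable size bears on this change, so neither direction nor size can be drawn from the two compounds shown. Compound 3 is therefore expected to stay near the limit, with an estimate of 100000 nM and a range from 20000 nM to 1000000 nM. The step from compound 2 to compound 3 is thus expected to be a number no higher from compound 2 to compound 3 (the limit leaves the size open).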

Compound 3, inhibition constant: > 100000 nM
Compound 3 gave a limit, no number (the forecaster's own chance of this, stated with the estimate: 80%); the middle value lies on the limit itself.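

Among the compounds shown here, no step among compound 1, compound 2 and compound 3 can be read, because all three stand at a limit rather than a number: the limit of > 100000 nM in this assay, at which 3 of the 3 values shown sit. The compounds shown leave open whether fluoro, hydroxy or isopropoxy on the shared core differ in inhibition at all.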